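From a chloro to a methoxy substituent

The source may report more compounds than this note shows. Statements on the series, on what has been measured and on what is new or still open speak of the compounds shown alone.

Compound 1 `NC1=NC2(CCSCC2)N(OCCCOc2cccc(Br)c2)C(N)=N1` gives 84.2% in an assay on isolated protein for inhibition of Dihydrofolate reductase (Homo sapiens), read by spectrophotometry, using NADPH, with stated times of 5 s and 6 min, tested at 5 uM; on this read-out lower numbers stand for a weaker effect and higher numbers for a stronger effect at the one concentration tested. Compound 2 `NC1=NC2(CCSCC2)N(OCCCOc2ccc(Cl)cc2)C(N)=N1` gives > 90% in this assay; that value is a limit of the assay, not a number: the limit of > 90% in this assay, at which 1 of the 2 values shown sits. Going by the values given here, the only measured step, a number at least 5.8 percentage points higher from compound 1 to compound 2 (that floor lies within the scatter), alters a different part of the molecule and so offers little guidance here. Compound 3 `COc1ccc(OCCCON2C(N)=NC(N)=NC23CCSCC3)cc1` differs from compound 2 by methoxy in place of chloro on an aromatic carbon. Compound 3 is expected to show a step of a number at least 5 percentage points lower from compound 2 to compound 3 (that floor lies within the scatter), within the scatter or slightly downward. Compound 3 is therefore estimated at 85%, in the range 70% to 95%.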

Compound 3, a percentage reported as inhibition, at one concentration (the size of the read-out at that concentration, not a potency): 81.3%
For compound 3 the middle estimate is 3.7 percentage points above the measured one; the range from low to high includes it.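

Methoxy in place of chloro on the aromatic carbon gives a number at least 8.7 percentage points lower from compound 2 to compound 3 (that floor lies within the scatter) in this assay. Going by these compounds, compound 2 sits at a limit of the assay rather than a number, so the true size of this step stays unknown: the limit of > 90% in this assay, at which 1 of the 3 values shown sits. 4-Methoxyphenyl in place of 3-bromophenyl gives a number 2.9 percentage points lower from compound 1 to compound 3 (within the scatter), so these two aromatic ends are not separated here.

Open, on these data alone, is whether an amine or a carboxylic acid on this aromatic carbon would hold the read-out at this level. Also open, as far as these compounds go, is how far chloro and methoxy truly differ, which a reading clear of the limit would be needed to settle.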